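A few compounds are considered here, and "the series" means these few. Any claim that something is new, unique, unknown or untested is made for them only; others in the source may bear on it.

Compound 3 `CCOC(=O)c1c[nH]nc1N/C=C1\C(=O)N(c2ccccc2)N=C1c1ccccc1` is the reference point for the step described here. In a functional assay on MDA-MB-361 cells (Homo sapiens) for antiproliferative activity, read by MTT assay, with a stated time of 72 h (on this read-out higher numbers stand for weaker inhibition and lower numbers for stronger inhibition), compound 3 gives 24700 nM, the lowest of the three numbers measured. Compound 1 `CCOC(=O)c1c[nH]nc1N/C=C1\C(=O)NN=C1c1ccccc1` gives 121000 nM, and compound 2 `O=C1NN=C(c2ccccc2)/C1=C/Nc1cc(-c2ccccc2)[nH]n1` gives 42700 nM, which sits close to compound 3. Among the measured compounds shown here, the only step measured between two compounds that differ in a single place is a 4.9-fold lower number from compound 1 to compound 3 (0.69 log units; beyond the scatter), a modest but real gain when the amide-type ring nitrogen carries a phenyl group instead of hydrogen.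

Compound 4 `O=C1/C(=C\Nc2cc[nH]n2)C(c2ccccc2)=NN1c1ccccc1` keeps that phenyl on the ring nitrogen and changes another part of the molecule: hydrogen in place of ethoxycarbonyl on an aromatic carbon. For the measured compounds named here, none of the measured steps involves the ethoxycarbonyl group directly, so no single-change step bears on this. Going by the values given here, the only hint comes from compound 1 and compound 2, whose two values show that replacing the ethoxycarbonyl by phenyl goes with a lower number, but that says nothing certain about replacing it by a bare hydrogen. The expected step from compound 3 to compound 4 is therefore a 1.6-fold higher number from compound 3 to compound 4 (0.21 log units; within the scatter), a small loss that may well stay within the scatter. Compound 4 is expected to give about 40000 nM, estimated to lie between 10000 nM and 150000 nM.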

Compound 4, half-maximal inhibitory concentration: 51000 nM
Beside the measured number, compound 4's estimate is 1.3-fold (0.11 log units) below it; the range from low to high includes it.
By their numbers in this assay, from the lowest: compounds 3, 2 and 4 (each within the scatter of the next, the first and the last beyond it); then compound 1.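

Among the compounds shown here, this is the first single-place change measured at this aromatic carbon of the five-membered aromatic ring with 2 nitrogen. In this assay, with the phenyl on the ring nitrogen held in place, replacing ethoxycarbonyl by hydrogen gives a 2.1-fold higher number from compound 3 to compound 4 (0.31 log units; beyond the scatter) and so moves the number just past the usual scatter. The ethoxycarbonyl therefore contributes to the lower number of compound 3, but only modestly, and nothing shown here explains how it does so.

The compounds shown leave open whether this contribution belongs to the ethoxycarbonyl specifically, which a carboxylic acid, a primary amide or a simple methyl group on the same carbon would help to test. For the compounds shown here, they also leave open whether losing the ethoxycarbonyl would cost the same with hydrogen rather than phenyl on the ring nitrogen, as in compound 1, since the single step read here comes from one pair of compounds that both carry the phenyl.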